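Swapping a heteroring in a diphenylmethyl sulfoxide series

A few compounds are considered here, and "the series" means these few. Any claim that something is new, unique, unknown or untested is made for them only; others in the source may bear on it.

The three measured compounds share a diphenylmethyl sulfoxide core carrying a five-membered ring on the chain carbon bound to a sulfur. Compound 1 `COC1NN=C(C[S+]([O-])C(c2ccccc2)c2ccccc2)S1` gives 108000 nM in an assay on HEK293 cells for inhibition of sodium-dependent dopamine transporter (Homo sapiens), read by scintillation counting, with stated times of 5 min and 1 min (a higher number here means a weaker inhibitor, a lower number a stronger inhibitor), which places it second highest of the three numbers. Compound 2 `CC(C)c1nnsc1C[S+]([O-])C(c1ccccc1)c1ccccc1` gives 69100 nM, and the step of a 1.6-fold lower number from compound 1 to compound 2 (0.19 log units; within the scatter) lies within the scatter. Compound 3 `Cc1scc(C[S+]([O-])C(c2ccccc2)c2ccccc2)c1C` gives 284000 nM, a modest step of a 2.6-fold higher number from compound 1 to compound 3 (0.42 log units; beyond the scatter); the step of a 4.1-fold higher number from compound 2 to compound 3 (0.61 log units; beyond the scatter) is likewise modest.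

Compound 4 `Cc1noc(C[S+]([O-])C(c2ccccc2)c2ccccc2)n1` has not yet been measured. The change from compound 1 is a group of 6 heavy atoms (3 carbon, 2 nitrogen, 1 oxygen; one five-membered aromatic ring with 3 hetero atoms) in place of a group of 7 heavy atoms (3 carbon, 2 nitrogen, 1 oxygen, 1 sulfur; one five-membered non-aromatic ring with 3 hetero atoms), on a saturated chain carbon bound to a sulfur. Within the data shown here, the step that bears on it most closely is the one from compound 1 to compound 2, where a five-membered aromatic ring with 3 hetero atoms also replaced the non-aromatic ring, and that step stayed within the scatter. The step to compound 3, with an aromatic ring of only 1 hetero atom, went modestly the other way. Because of a 1.6-fold lower number from compound 1 to compound 2 (0.19 log units; within the scatter), compound 4 is expected to sit close to compound 1, with a step of a 1.2-fold lower number from compound 1 to compound 4 (0.08 log units; within the scatter) that need not exceed the scatter. The estimate for compound 4 is 90000 nM, within a range of 30000 nM to 270000 nM.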

Compound 4, half-maximal inhibitory concentration: 56700 nM
Estimate against measurement, compound 4: 1.6-fold (0.20 log units) above, within the range that was stated.
By their numbers in this assay, from the lowest: compounds 4, 2 and 1 (each within the scatter of the next); then compound 3.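

In this assay the 3-methyl-1,2,4-oxadiazol-5-yl group gives a second five-membered aromatic ring with 3 hetero atoms that stays level with the non-aromatic ring it replaces, with a 1.9-fold lower number from compound 1 to compound 4 (0.28 log units; within the scatter), and level with the ring of compound 2, with a 1.2-fold lower number from compound 2 to compound 4 (0.09 log units; within the scatter). The sulfur-free ring of compound 4 therefore shows that, among these compounds, a ring sulfur is not needed to hold this level on a saturated chain carbon bound to a sulfur, while compound 3 stands apart from the other three, as a 5.0-fold lower number from compound 3 to compound 4 (0.70 log units; beyond the scatter) shows once more. Nothing measured here explains why the 4,5-dimethylthiophen-3-yl group stands apart from the other three rings.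

The compounds shown leave open how a carboxylic acid or a primary amine would compare at this place, and whether a plain phenyl group would fall with compound 3 or with compound 1, compound 2 and compound 4. They also leave open what the methyl of the 3-methyl-1,2,4-oxadiazol-5-yl group contributes, which an ethyl or a longer chain in its stead could test.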